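Methoxyphenyl isomers on the lactam nitrogen of the aryl-sulfonamide series

The source may hold more compounds than are shown below. What is called first, only, known or untested is meant among the compounds shown, and "the series" means these compounds.

In a functional assay on A-375 cells (Homo sapiens) for antiproliferative activity, read by MTT assay, with a stated time of 72 h (on this read-out lower numbers stand for stronger inhibition and higher numbers for weaker inhibition), compound 2 `COc1cccc(N2C(=O)COc3ccc(-c4cnc(Cl)c(NS(=O)(=O)c5ccc(F)cc5)c4)cc32)c1` gives only a limit, > 40000 nM, not a number. Compound 1 `O=C1COc2ccc(-c3cccc(NS(=O)(=O)c4ccc(F)cc4)c3)cc2N1c1ccccc1` likewise reaches only the limit of > 40000 nM in this assay. Among the measured compounds shown here, compound 3 `COc1ncc(-c2ccc3c(c2)N(c2ccc(Cl)cc2)C(=O)CO3)cc1NS(=O)(=O)c1ccc(F)cc1`, carrying 4-chlorophenyl on the same amide-type nitrogen in a ring, is the single member with a numeric value, 24100 nM in this assay, which sits close to that boundary. Two of the three values shown rest on (the limit of > 40000 nM in this assay, at which 2 of the 3 values shown sit), so compound 2 stands at the weak end of what this assay can resolve, with no ordering possible among the three.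

Compound 4 `COc1ccc(N2C(=O)COc3ccc(-c4cnc(Cl)c(NS(=O)(=O)c5ccc(F)cc5)c4)cc32)cc1` differs from compound 2 only by 4-methoxyphenyl in place of 3-methoxyphenyl on an amide-type nitrogen in a ring. For the measured compounds named here, no measured pair isolates this change, so no direction can be read from the data; with compound 3 at 24100 nM as the only numeric anchor for this position, a step of at most the usual scatter is expected, in either direction. Compound 4 is estimated at 40000 nM in this assay, between 15000 nM and 100000 nM, and the expected step of a number no higher from compound 2 to compound 4 (the limit leaves the size open) is therefore essentially none; a limit rather than a number is the more likely outcome.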

Compound 4, half-maximal inhibitory concentration: 32700 nM
The estimate for compound 4 lay 1.2-fold (0.09 log units) above the measured number, within the range that was stated.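

With 4-methoxyphenyl in place of 3-methoxyphenyl on the amide-type nitrogen in a ring, the series gains its first pair that isolates a change at this position, and this assay shows an at least 1.2-fold lower number from compound 2 to compound 4 (0.08 log units; that floor lies within the scatter). Going by these compounds, the value of compound 2 is a limit, so the true size of this step remains unknown, and its printed floor does not separate the two methoxyphenyl isomers. Compound 4 does return a number, but the series as a whole remains crowded at the weak end of the read-out: the limit of > 40000 nM in this assay, at which 2 of the 4 values shown sit.

On these data alone, whether an aminophenyl group, a carboxyphenyl group or a phenyl bearing a longer alkoxy chain on this nitrogen would give a value clearly removed from that limit remains open. Also open, as far as these compounds go, is whether the same methoxyphenyl change would read differently on a different core.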